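A fluorine added where every value sits at the limit

The compounds below may be only part of what the source reports. "The series", "measured", "known", "first", "only" and "open" are said of these compounds alone.

Compound 3 `C/C(=N\OCC(N)=O)c1ccccc1` carries amino in place of hydroxy on the carbonyl carbon of compound 1 `C/C(=N\OCC(=O)O)c1ccccc1`. In a functional assay on the whole organism for inhibition, with Rattus norvegicus as the target, read by paw edema, with stated times of 1 h and 3 h, at a dose of 50 mg/kg by the oral route (a higher number here means more inhibition at the dose given (going by the name of the read-out), a lower number less inhibition), compound 3 gives only a limit, < 20%. Compound 1 likewise reaches only a limit, < 20%. Compound 2 `CSc1ccc(/C(C)=N/OCC(=O)O)cc1` carries methylsulfanyl in place of hydrogen on an aromatic carbon of compound 1. In this assay compound 2 also stops at a limit, < 20%. The two measured steps, a step that the two limits leave unreadable from compound 1 to compound 2 and a step that the two limits leave unreadable from compound 1 to compound 3, are unreadable since (the limit of < 20% in this assay, at which 3 of the 3 values shown sit). Compound 4 `C/C(=N\OCC(N)=O)c1ccc(F)cc1` differs from compound 3 by fluoro in place of hydrogen on an aromatic carbon. For the measured compounds named here, no measured step touches this change, so the expected step in this assay is a step that the limit leaves unreadable from compound 3 to compound 4, nothing beyond the scatter. Compound 4 is therefore estimated at 12%, within 0% to 30%.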

Compound 4, a percentage reported as inhibition, in the whole organism at one dose (the size of the read-out at that dose, not a potency): 20%
Compound 4: middle estimate off by 8 percentage points, on the low side; low and high end bracket the measured number.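

In this assay, fluoro in place of hydrogen on an aromatic carbon, para to a group of 8 heavy atoms, gives a number no lower from compound 3 to compound 4 (the limit leaves the size open). For the compounds shown here, compound 4, at 20%, is the first compound here to give a number rather than a limit. The size of this change stays unreadable because the series rests largely on one limit: the limit of < 20% in this assay, at which 3 of the 4 values shown sit.

Going by these compounds, it remains open whether chloro or methoxy at this position would give a number beyond that limit. On these data alone, it is also open whether fluoro would do the same on the carboxylic acid of compound 1.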